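The compounds below may be only part of what the source reports. "The series", "measured", "known", "first", "only" and "open" are said of these compounds alone.

In a functional assay on HCT-116 cells (Homo sapiens) for antiproliferative activity, read by MTT assay, with a stated time of 72 h (a lower number here means a stronger inhibitor, a higher number a weaker inhibitor), compound 1 `O=C1COc2ccc(-c3cnc(Cl)c(NS(=O)(=O)c4ccc(F)cc4)c3)cc2N1C1CCCCC1` gives > 40000 nM, which is a limit of the assay and not a number. Compound 2 `O=C1COc2ccc(-c3cccc(NS(=O)(=O)c4ccc(F)cc4)c3)cc2N1c1ccccc1` gives > 40000 nM, and this too is a limit. The picture so far is therefore a single one: the limit of > 40000 nM in this assay, at which 2 of the 2 values shown sit. Among the compounds with values here, compound 1 thus has no exact potency to start from, and no pair of measured compounds shows how large a structural change can be in its effect on the read-out.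

The next compound, compound 3 `O=C1COc2ccc(-c3cnc(Cl)c(NS(=O)(=O)c4ccc(F)cc4)c3)cc2N1c1ccc(Cl)cc1`, keeps the core of compound 1 and carries 4-chlorophenyl in place of cyclohexyl on an amide-type nitrogen in a ring. With only limits in hand, any forecast is uncertain. A modest move toward stronger inhibition in this assay is expected, although a result that again reports only a limit would be no surprise. The expected size of this move is an at least 2.6-fold lower number from compound 1 to compound 3 (0.42 log units; beyond the scatter). For compound 3 the estimated half-maximal inhibitory concentration is 15000 nM, with an expected range from 2000 nM to 40000 nM.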

Compound 3, half-maximal inhibitory concentration: 27900 nM
Compound 3: the middle estimate sits 1.9-fold (0.27 log units) below what was measured, and the stated range covers the measured number.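

Putting 4-chlorophenyl in place of cyclohexyl on the amide-type nitrogen in a ring gives an at least 1.4-fold lower number from compound 1 to compound 3 (0.15 log units; that floor lies within the scatter), so in this assay this position now carries a compound with an exact number, compound 3 at 27900 nM. As far as these compounds go, compound 1 gives > 40000 nM, which is a limit of the assay and not a number, so the true size of this step is unknown: it may be larger than its floor, but the floor alone does not show a change beyond the scatter. Exact readings remain the exception in this assay: the limit of > 40000 nM in this assay, at which 2 of the 3 values shown sit.

The compounds shown leave open whether any shift comes from the aromatic ring itself or from its chlorine, since no compound on this core carries an unsubstituted phenyl on that nitrogen. From the compounds shown here alone, it also remains open how this position would respond to a 4-methoxyphenyl group, or to a chain ending in an amine, and whether any such group could bring the number well away from the limit.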